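This account rests on a few compounds, and the source may have more. Where it says the series, first, only, none or still open, it means among the compounds named here.

Values in a functional assay on MGC-803 cells (Homo sapiens) for inhibition, read by MTT assay, with a stated time of 72 h; a higher number here means a weaker inhibitor, a lower number a stronger inhibitor:
compound 1 `Cc1cc(N2CC[C@@H](C)[C@@H](N(C)c3ncnc4[nH]ccc34)C2)n2ncnc2n1`: 4350 nM
compound 2 `Cc1cc(N2CC[C@@H](C)[C@@H](N(C)c3ncnc4[nH]ccc34)C2)n2nc(SCc3ccccc3Br)nc2n1`: 27000 nM

Of these two, compound 2 at 27000 nM carries the higher number, which makes it the weaker inhibitor of the pair. For the measured compounds named here, the only measured step is a 6.2-fold higher number from compound 1 to compound 2 (0.79 log units; beyond the scatter), with (2-bromobenzyl)sulfanyl in place of hydrogen on an aromatic carbon.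

Compound 3 `Cc1cc(N2CC[C@@H](C)[C@@H](N(C)c3ncnc4[nH]ccc34)C2)n2nc(SCCc3ccccc3)nc2n1` has not yet been measured. Its difference from compound 2 is benzyl in place of 2-bromophenyl on a saturated chain carbon bound to a sulfur, or (2-bromobenzyl)sulfanyl to phenethylsulfanyl. Both the leaving and the entering group hold one six-membered aromatic ring of carbon only.

The measured step bears on this only indirectly, since it records the gain of the whole sulfanyl group and not a swap within it. Going by the values given here, no measured step shows a change at this place, so in this assay no step beyond the scatter is expected, with a slight lean toward a lower number.

For compound 3 the estimated value is 20000 nM, with an expected range of 8000 nM to 50000 nM. This estimate means an expected 1.4-fold lower number from compound 2 to compound 3 (0.13 log units; within the scatter).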

Compound 3, half-maximal inhibitory concentration: 6190 nM
Compound 3: middle estimate off by 3.2-fold (0.51 log units), on the high side; measured number below the stated range.
By their numbers in this assay, from the lowest: compounds 1 and 3 (each within the scatter of the next); then compound 2.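

In this assay, a sulfanyl group on this aromatic carbon does not by itself bring the higher number seen for compound 2: replacing 2-bromophenyl with benzyl on the saturated chain carbon bound to the sulfur gives a 4.4-fold lower number from compound 2 to compound 3 (0.64 log units; beyond the scatter). Phenethylsulfanyl in place of hydrogen gives a 1.4-fold higher number from compound 1 to compound 3 (0.15 log units; within the scatter), so compound 1 and compound 3 cannot be told apart, and this place tolerates at least this one sizeable sulfanyl group without a step beyond the scatter. The change from 2-bromobenzyl to phenethyl both removes the bromine and alters the chain, and these compounds do not separate the two; nothing available here bears on why the number moves.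

Benzylsulfanyl without bromine and a phenethylsulfanyl group carrying bromine would separate those two changes. Also open, going by these compounds, is how a longer chain such as 3-phenylpropylsulfanyl, or an amine or carboxylic acid at the end of the chain, would read here, and whether any group at this place can give a number lower than that of compound 1 beyond the scatter.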